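This account rests on a few compounds, and the source may have more. Where it says the series, first, only, none or still open, it means among the compounds named here.

Measured in a functional assay on Jurkat cells (Homo sapiens) for inhibition, read by CCK-8 assay, with a stated time of 48 h; a higher number here means a weaker inhibitor of growth, a lower number a stronger inhibitor of growth:
- compound 1 `Cc1ccccc1Nc1nc(Nc2ccc(N3CCN(C)CC3)cn2)ncc1Cl` gives 8080 nM
- compound 2 `CCc1ccc(Nc2nc(Nc3ccc(N4CCN(C)CC4)cn3)ncc2Cl)cc1` gives 11100 nM
- compound 3 `CC(C)c1ccc(Nc2nc(Nc3ccc(N4CCN(C)CC4)cn3)ncc2Cl)cc1` gives 7530 nM

Compound 3 lies within the scatter of both neighbours, with a 1.1-fold lower number from compound 1 to compound 3 (0.03 log units; within the scatter) and a 1.5-fold lower number from compound 2 to compound 3 (0.17 log units; within the scatter). Compound 4 `COc1cccc(Nc2nc(Nc3ccc(N4CCN(C)CC4)cn3)ncc2Cl)c1` has 3-methoxyphenyl in place of 4-isopropylphenyl on a nitrogen on an aromatic ring. The closest evidence is the other changes of this aryl group, a 1.4-fold higher number from compound 1 to compound 2 (0.14 log units; within the scatter) and a 1.1-fold lower number from compound 1 to compound 3 (0.03 log units; within the scatter), both within the scatter. Within the data shown here, no measured compound carries 3-methoxyphenyl, so this evidence is indirect. No step beyond the scatter is expected, and the estimated step reads a 1.1-fold higher number from compound 3 to compound 4 (0.05 log units; within the scatter). The expected value for compound 4 is 8500 nM, with an estimated range of 4500 nM to 16000 nM.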

Compound 4, concentration for 50% growth inhibition: 15800 nM
For compound 4 the middle estimate is 1.9-fold (0.27 log units) below the measured one; measured number inside the range.
By their numbers in this assay, from the lowest: compounds 3, 1, 2 and 4 (each within the scatter of the next, the first and the last beyond it).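

In this assay, among these compounds, the change to 3-methoxyphenyl on this nitrogen gives the first step beyond the scatter (a 2.1-fold higher number from compound 3 to compound 4 (0.32 log units; beyond the scatter)), and that step is modest. Against the other aryl groups the same change stays within the scatter (a 1.4-fold higher number from compound 2 to compound 4 (0.15 log units; within the scatter); a 2.0-fold higher number from compound 1 to compound 4 (0.29 log units; within the scatter)), so the separation appears only against 4-isopropylphenyl. No measured evidence bears on the origin of this step.

Still open, from the compounds shown here alone, is whether any aryl group at this nitrogen can move the number far from this range. An amine or a carboxylic acid on the phenyl ring would test that.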